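Fluoro removal on the pyridinyl amide: cytotoxicity notes

The compounds below may be only part of what the source reports. "The series", "measured", "known", "first", "only" and "open" are said of these compounds alone.

compound 1 `CC(C)n1ncc2c(C(=O)Nc3cncnc3)cc(-c3cccs3)nc21`: 20000 nM
compound 2 `CC(C)n1ncc2c(C(=O)Nc3ccc(F)cn3)cc(-c3cccs3)nc21`: > 200000 nM

In an ADME assay on LLC-MK2 cells (Macaca mulatta) for cytotoxicity, read by spectrophotometry and crystal violet staining, with a stated time of 4 days (on this read-out lower numbers stand for higher toxicity in this test and higher numbers for lower toxicity in this test), compound 1 gives 20000 nM. For compound 2 the read-out is a limit of the assay, > 200000 nM (the limit of > 200000 nM in this assay, at which 1 of the 2 values shown sits), so compound 2 stands at the upper edge of the numbers shown. Compound 3 `CC(C)n1ncc2c(C(=O)Nc3ccccn3)cc(-c3cccs3)nc21` differs from compound 2 by hydrogen in place of fluoro on an aromatic carbon. Going by the values given here, the one measured step, an at least 10-fold higher number from compound 1 to compound 2 (1.00 log units; beyond the scatter), exchanges the whole ring rather than a fluoro and bears only loosely on this change. The step is expected to stay within the scatter, an at least 1.3-fold lower number from compound 2 to compound 3 (0.12 log units; that floor lies within the scatter). Compound 3 is estimated at 150000 nM, range 40000 nM to 400000 nM.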

Compound 3, half-maximal cytotoxic concentration: > 200000 nM
Compound 3: no number, only a limit; the forecaster's own chance of this, stated with the estimate: 50%; at least 1.3-fold (0.12 log units) between middle value and limit.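

In this assay compound 3 is a limit of the assay and not a number, and it sits at the same limit as compound 2: the limit of > 200000 nM in this assay, at which 2 of the 3 values shown sit.

The fluoro is therefore not required for the high reading, since pyridin-2-yl in place of pyrimidin-5-yl gives an at least 10-fold higher number from compound 1 to compound 3 (1.00 log units; beyond the scatter) on its own. The step from compound 2 to compound 3 cannot be read, so the effect of removing the fluoro stays hidden.

Going by these compounds, whether compound 2 and compound 3 differ at all remains open. Also open, on these data alone, is whether a methoxy or an amine at this position would bring the number back into the readable range.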